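Swapping a Bromo for a Methoxy on the Coumarin Ring

The compounds below may be only part of what the source reports. "The series", "measured", "known", "first", "only" and "open" are said of these compounds alone.

Of the compounds shown here, three that share one core have been measured in an assay on isolated protein for inhibition of Amine oxidase [flavin-containing] B (Homo sapiens), read by fluorescence, with a stated time of 15 min; a lower number here means a stronger inhibitor, a higher number a weaker inhibitor. Compound 1 `COc1ccc(/C=C/c2cc(OC)cc(OC)c2/C=C/C(=O)c2cc3ccccc3oc2=O)cc1` gives 9170 nM. Compound 2 `COc1ccc(/C=C/c2cc(OC)cc(OC)c2/C=C/C(=O)c2cc3ccc(Br)cc3oc2=O)cc1` carries a bromo on an aromatic carbon and gives 55300 nM, the highest of the three numbers and therefore the weakest inhibitor here. Compound 3 `COc1ccc(/C=C/c2cc(OC)cc(OC)c2/C=C/C(=O)c2cc3cc(F)ccc3oc2=O)cc1` carries a fluoro at the same place and gives 10200 nM. The step of a 6.0-fold higher number from compound 1 to compound 2 (0.78 log units; beyond the scatter) is beyond the scatter, while the step of a 1.1-fold higher number from compound 1 to compound 3 (0.05 log units; within the scatter) is not, and a 5.4-fold lower number from compound 2 to compound 3 (0.73 log units; beyond the scatter).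

Compound 4 `COc1ccc(/C=C/c2cc(OC)cc(OC)c2/C=C/C(=O)c2cc3ccc(OC)cc3oc2=O)cc1` is not yet measured. It differs from compound 2 by methoxy in place of bromo on an aromatic carbon. Since removing the bromo in favour of hydrogen or fluoro brought the number down, the expectation for compound 4 is a lower number than compound 2, though the methoxy is a different group and its effect has not been seen in this series. The estimated step is a 3.7-fold lower number from compound 2 to compound 4 (0.57 log units; beyond the scatter). Compound 4 is thus expected at 15000 nM, with a range from 6000 nM to 40000 nM.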

Compound 4, half-maximal inhibitory concentration: 4200 nM
Compound 4: the middle estimate sits 3.6-fold (0.55 log units) above what was measured; the whole stated range lies above it.
By their numbers in this assay, from the lowest: compound 4; then compounds 1 and 3 (each within the scatter of the next); then compound 2.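

At this carbon of the coumarin ring, an added group does not have to weaken inhibition: in this assay the methoxy gives a 2.2-fold lower number from compound 1 to compound 4 (0.34 log units; beyond the scatter), whereas the bromo gave a 6.0-fold higher number from compound 1 to compound 2 (0.78 log units; beyond the scatter). Exchanging one for the other gives a 13-fold lower number from compound 2 to compound 4 (1.12 log units; beyond the scatter), the only large step among these compounds, so at this position the identity of the group matters, not merely whether the hydrogen is replaced. Nothing available here explains why these two groups differ so much.

On these data alone, it remains open whether a hydroxyl, an amine or a longer chain such as ethoxy at this same carbon would match the methoxy or go beyond it. A comparison with the hydroxyl would also help show whether the oxygen or the attached methyl carbon goes with the lower number.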